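Methoxy, ethoxy and propoxy on the shared core

This account rests on a few compounds, and the source may have more. Where it says the series, first, only, none or still open, it means among the compounds named here.

The three measured compounds share one core. Compound 1 `Oc1ccccc1CNc1ccc(-c2ccc(F)cc2)cc1` carries fluoro on an aromatic carbon; in compound 2 `COc1ccc(-c2ccc(NCc3ccccc3O)cc2)cc1` methoxy stands in its place and in compound 3 `CCOc1ccc(-c2ccc(NCc3ccccc3O)cc2)cc1` ethoxy. In a functional assay on Jurkat cells (Homo sapiens) for activation, with a stated time of 24 h (on this read-out higher numbers stand for an effect only at larger amounts of compound and lower numbers for an effect already at smaller amounts), compound 1 gives 3860 nM, compound 2 gives 580 nM and compound 3 gives 520 nM. Compound 3 gives the lowest of the three numbers, but its gap to compound 2 is within the scatter, so no order between those two is claimed; only compound 1 is clearly separated, by a 6.7-fold lower number from compound 1 to compound 2 (0.82 log units; beyond the scatter) and a 7.4-fold lower number from compound 1 to compound 3 (0.87 log units; beyond the scatter).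

Compound 4 `CCCOc1ccc(-c2ccc(NCc3ccccc3O)cc2)cc1` differs from compound 3 by methyl in place of hydrogen on a saturated chain carbon, two bonds along the chain from an oxygen on an aromatic ring. The step that bears on it most directly, methyl in place of hydrogen on a saturated chain carbon bound to an oxygen on an aromatic ring, gave a 1.1-fold lower number from compound 2 to compound 3 (0.05 log units; within the scatter). The two larger steps concern methoxy or ethoxy in place of fluoro and do not speak to chain length. For compound 4 in this assay the expected step is a 1.0-fold lower number from compound 3 to compound 4 (0.02 log units; within the scatter), none beyond the scatter. Compound 4 is estimated at 500 nM, with a range of 250 nM to 1100 nM.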

Compound 4, half-maximal effective concentration: "not active" (no number reported)
No number was reported for compound 4, so the estimate cannot be set against anything.
By their numbers in this assay, from the lowest: compounds 3 and 2 (each within the scatter of the next); then compound 1.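

Going by these compounds alone, compound 4 is recorded as not active in this assay with no number, so no step from compound 3 to compound 4 can be read. No measured evidence bears on this result. The compounds shown leave open how propoxy compares numerically with ethoxy on the shared core.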